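A few compounds are considered here, and "the series" means these few. Any claim that something is new, unique, unknown or untested is made for them only; others in the source may bear on it.

Compound 3 `O=C(NC1CCN(Cc2ccc(Cl)cc2)CC1)c1ccc2ccccc2c1` has the lowest number of the three measured compounds in an assay on isolated protein for displacement of a labelled ligand from D(4) dopamine receptor (Homo sapiens) (a higher number here means a weaker inhibitor, a lower number a stronger inhibitor), where compound 3 gives 37 nM. The nearest measured compound is compound 2 `Cc1ccccc1CN1CCC(NC(=O)c2cccc3ccccc23)CC1`, which gives 155 nM, and furthest is compound 1 `O=C(NC1CCN(Cc2ccccc2Cl)CC1)c1cccc2ccccc12`, which gives 329 nM. Among the compounds with values here, the only measured step between compounds differing in one place is a 2.1-fold lower number from compound 1 to compound 2 (0.33 log units; beyond the scatter), an exchange of one small group for another on the aromatic ring that hangs from the ring amine.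

Compound 4 `COc1cccc(CN2CCC(NC(=O)c3ccc4ccccc4c3)CC2)c1` differs from compound 3 in that same region: 3-methoxyphenyl in place of 4-chlorophenyl on a saturated chain carbon bound to an amine nitrogen in a ring. Within the data shown here, the step from compound 1 to compound 2 bears on this only loosely, since it swaps a different pair of groups, and no measured compound carries a methoxy group. That one related step was modest, so a modest step is expected here too, with no secure direction; as compound 3 already holds the best number, a slight weakening is expected, a 1.5-fold higher number from compound 3 to compound 4 (0.17 log units; within the scatter). The estimate for compound 4 is 55 nM, within a range from 15 nM to 200 nM.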

Compound 4, inhibition constant: 16 nM
Compound 4: the middle estimate sits 3.4-fold (0.54 log units) above what was measured, within the range that was stated.
By their numbers in this assay, from the lowest: compound 4; then compound 3; then compound 2; then compound 1.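

In this assay, the change from 4-chlorophenyl to 3-methoxyphenyl gives a 2.3-fold lower number from compound 3 to compound 4 (0.36 log units; beyond the scatter), so this part of the molecule can still yield a stronger inhibitor than the best earlier compound. Compound 4 also shows that the chlorine is not needed to reach this level, although the step changes both the group and its place on the ring, so it cannot show which of the two accounts for the difference. No measurement here gives a reason for the gain.

The compounds shown leave open whether the oxygen of the methoxy group matters, which a hydroxy group or an ethoxy group in its place could begin to test. They also leave open whether the same 3-methoxybenzyl group would give a similar step on the core of compound 1.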